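A few compounds are considered here, and "the series" means these few. Any claim that something is new, unique, unknown or untested is made for them only; others in the source may bear on it.

Measured compounds:
- Compound 1, `Cc1cccc(N2CCN(C(=O)CN3C(=O)CC(C)(c4ccccc4)C3=O)CC2)c1`: 100 mg/kg
- Compound 2, `CC1(c2ccccc2)CC(=O)N(CC(=O)N2CCN(c3cccc(Cl)c3)CC2)C1=O`: 300 mg/kg
- Compound 3, `CC1(c2ccccc2)CC(=O)N(CC(=O)N2CCN(c3ccccc3Cl)CC2)C1=O`: "not active" (no number reported)

The three compounds share one core and differ only in the group carried on an amine nitrogen in a ring. In a functional assay on the whole organism (strain CD-1) with Mus musculus as the target, in the maximal electroshock model, with a stated time of 0.5 h (on this read-out lower numbers stand for an effect already at smaller amounts and higher numbers for an effect only at larger amounts of compound), compound 1 gives 100 mg/kg and compound 2 gives 300 mg/kg, a difference that is a 3.0-fold higher number from compound 1 to compound 2 (0.48 log units; beyond the scatter). Compound 3 is reported in this assay as "not active" (no number reported), so no number stands for it; against compound 2, which gives 300 mg/kg, compound 3 shows only that its chloro placed differently on the ring went with no recorded effect at the amounts tried.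

Compound 4, `CC1(c2ccccc2)CC(=O)N(CC(=O)N2CCN(c3ccc(Cl)c(Cl)c3)CC2)C1=O`, is not yet measured. It differs from compound 3 by 3,4-dichlorophenyl in place of 2-chlorophenyl on an amine nitrogen in a ring.

Within the data shown here, only one measured step exists, from compound 1 to compound 2, and it concerns a chloro in place of a methyl, not a second chloro or a change of ring position, so it bears on the present step only loosely and was modest in size. With compound 3 carrying no number, no direction for this assay can be read from the data; a return to an active dose of the size of compound 2 is as plausible as another inactive result.

For compound 4 in this assay the expected value is 300 mg/kg, with a range from 100 mg/kg to 600 mg/kg.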

Compound 4, minimum effective dose: "not active" (no number reported)
For compound 4 the study gives words and no number, and the estimate cannot be compared.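

In this assay, among these compounds, compound 3 and compound 4 are both reported in words as not active, without a number, so no step between them can be read. No available evidence bears on this result. The compounds shown leave open whether compound 3 and compound 4 differ at all in this test.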